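From 3,5-dimethoxyphenyl to 3,5-dimethylphenyl on the shared core

A few compounds are considered here, and "the series" means these few. Any claim that something is new, unique, unknown or untested is made for them only; others in the source may bear on it.

Going by the values given here, in a functional assay on OVCAR-3 cells (Homo sapiens) for antiproliferative activity, read by spectrophotometry, with a stated time of 2 days (on this read-out higher numbers stand for weaker inhibition of growth and lower numbers for stronger inhibition of growth), compound 3 `COc1cc(Nc2ncc(C(F)(F)F)c(N3Cc4cccc(N(C)S(C)(=O)=O)c4C3)n2)cc(OC)c1` gives 630 nM, the only true number so far. Compound 1 `COc1ccc(C(F)(F)F)cc1Nc1ncc(C(F)(F)F)c(N2Cc3cccc(N(C)S(C)(=O)=O)c3C2)n1` gives > 30000 nM, which is a limit of the assay. Compound 2 `Cc1ccc(Nc2ncc(C(F)(F)F)c(N3Cc4cccc(N(C)S(C)(=O)=O)c4C3)n2)c(Cl)c1` gives > 30000 nM, again a limit. Between these two, the data show a step that the two limits leave unreadable from compound 1 to compound 2. Compound 3 stands clearly on the stronger side of both, with an at least 47-fold lower number from compound 1 to compound 3 (1.67 log units; beyond the scatter) and an at least 47-fold lower number from compound 2 to compound 3 (1.67 log units; beyond the scatter).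

The next compound is compound 4 `Cc1cc(C)cc(Nc2ncc(C(F)(F)F)c(N3Cc4cccc(N(C)S(C)(=O)=O)c4C3)n2)c1`, and the change is 3,5-dimethylphenyl in place of 3,5-dimethoxyphenyl on a nitrogen on an aromatic ring. Among the compounds with values here, no measured step makes this exact exchange. The two large steps to compound 3 bear on it only indirectly, but they show that this assay can respond strongly to the group at this place. The 3,5-dimethylphenyl group differs from 3,5-dimethoxyphenyl less than 2-methoxy-5-(trifluoromethyl)phenyl or 2-chloro-4-methylphenyl does. A moderate move towards weaker inhibition is therefore expected, much smaller than those two steps, though a fall to the limit cannot be excluded. The expected step is a 2.4-fold higher number from compound 3 to compound 4 (0.38 log units; beyond the scatter). For compound 4 the estimated value is 1500 nM, with an expected range of 300 nM to 12000 nM.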

Compound 4, concentration for 50% growth inhibition: > 30000 nM
Compound 4 ended at the assay's limit (the forecaster's own chance of this, stated with the estimate: 15%); middle value at least 20-fold (1.30 log units) from the limit.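

In this assay, putting 3,5-dimethylphenyl in place of 3,5-dimethoxyphenyl on a nitrogen on an aromatic ring gives an at least 47-fold higher number from compound 3 to compound 4 (1.67 log units; beyond the scatter), so this position responds strongly to this exchange as well. The earlier large steps to compound 3 each replaced one differently arranged phenyl with another, whereas this step exchanges only the two methoxy groups for two methyl groups, taking the count from 2 hydrogen-bond acceptors to 0, although the data do not tie the loss of activity to that count. The steps among compound 1, compound 2 and compound 4 cannot be read, because all three sit at the same limit, so no order among them can be given: the limit of > 30000 nM in this assay, at which 3 of the 4 values shown sit.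

Within these compounds, the 3,5-dimethoxyphenyl group is the only one with a true number, so it remains open whether both methoxy groups are needed or one would suffice alongside a methyl group. Going by these compounds, it is equally open whether a hydroxyl, an ethoxy or an amine in place of the methoxy groups would keep the growth inhibition seen with compound 3.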